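A nitro substituent on the core of compound 1

A few compounds are considered here, and "the series" means these few. Any claim that something is new, unique, unknown or untested is made for them only; others in the source may bear on it.

Compound 1 `CCn1c(/C=C2/C(=O)Nc3ccccc32)nc2ccccc21`: > 50000 nM, a limit of the assay
Compound 2 `CC(C)n1c(/C=C2/C(=O)Nc3ccccc32)nc2ccccc21`: 33500 nM
Compound 3 `Cn1c(/C=C2/C(=O)Nc3ccc(Br)cc32)nc2ccccc21`: > 50000 nM, a limit of the assay

In a functional assay on HGC cells (Homo sapiens) for cytotoxicity, read by MTT assay, with a stated time of 48 h (a higher number here means a weaker inhibitor, a lower number a stronger inhibitor), compound 1 gives > 50000 nM, which is a limit of the assay and not a number. Compound 3 likewise sits at a limit, > 50000 nM. Only compound 2 returns a number, 33500 nM. So compound 1 stands at the limit of > 50000 nM in this assay, at which 2 of the 3 values shown sit, and nothing places it more precisely than that.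

For the measured compounds named here, the single step measured between compounds that differ in one place is an at least 1.4-fold lower number from compound 1 to compound 2 (0.17 log units; that floor lies within the scatter), a change on the saturated chain carbon bound to the aromatic nitrogen, not on the fused ring.

Compound 4 `CCn1c(/C=C2/C(=O)Nc3ccc([N+](=O)[O-])cc32)nc2ccccc21` differs from compound 1 by nitro in place of hydrogen on an aromatic carbon. Going by the values given here, no measured step touches this position. Among the compounds with values here, compound 1 and compound 3 differ in more than one place, so their two values, both limits, show only that neither reaches a number in this assay. On that evidence no step beyond the scatter is expected for the change from compound 1 to compound 4, and the result is most likely another limit.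

Compound 4 is therefore estimated at 50000 nM, with a range of 20000 nM to 100000 nM in this assay.

This estimate means a step of a number no higher from compound 1 to compound 4 (the limit leaves the size open), which is expected to be within the scatter.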

Compound 4, half-maximal inhibitory concentration: > 50000 nM
Compound 4 ended at the assay's limit (the forecaster's own chance of this, stated with the estimate: 60%); the middle value lies on the limit itself.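

In this assay compound 4 gives > 50000 nM, a limit of the assay and not a number. Compound 1 also sits at a limit, so no step from compound 1 to compound 4 can be read: the limit of > 50000 nM in this assay, at which 3 of the 4 values shown sit.

The compounds shown leave open whether nitro in place of hydrogen on an aromatic carbon changes the number in this assay at all, and in which direction.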